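Swapping Bromine for Chlorine on the Phenylurea

A few compounds are considered here, and "the series" means these few. Any claim that something is new, unique, unknown or untested is made for them only; others in the source may bear on it.

Within the data shown here, in a functional assay on MCF7 cells (Homo sapiens) for inhibition, read by MTT assay, with a stated time of 72 h (on this read-out lower numbers stand for stronger inhibition and higher numbers for weaker inhibition), compound 2 `COc1cc(NC(C)CCCNC(=O)Nc2ccc(Br)cc2)c2ncccc2c1` gives 2600 nM, the lowest of the two numbers measured so far. Compound 1 `COc1cc(NC(C)CCCNC(=O)Nc2cccc(Cl)c2)c2ncccc2c1` gives 11000 nM in this assay. Among the measured compounds shown here, the one step between them is a 4.2-fold lower number from compound 1 to compound 2 (0.63 log units; beyond the scatter), with 4-bromophenyl in place of 3-chlorophenyl on an amide-type nitrogen. Compound 3 `COc1cc(NC(C)CCCNC(=O)Nc2ccc(Cl)cc2)c2ncccc2c1` has not yet been measured; it differs from compound 2 in a single place: chloro in place of bromo on an aromatic carbon. For the measured compounds named here, no measured step isolates this change. Going by the values given here, the only step available alters the substituent and the position named in it at once, so it cannot say what trading bromo for chloro by itself is worth. The expectation is a small change, no larger than the usual scatter, perhaps a slightly higher number. For compound 3 the expected step is a 1.3-fold higher number from compound 2 to compound 3 (0.13 log units; within the scatter). Compound 3 is estimated at 3500 nM, within a range of 1500 nM to 8000 nM.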

Compound 3, half-maximal inhibitory concentration: 12000 nM
Compound 3: middle estimate off by 3.4-fold (0.54 log units), on the low side; the measured number lies above the stated range.
By their numbers in this assay, from the lowest: compound 2; then compounds 1 and 3 (each within the scatter of the next).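

Within this assay the halogen alone matters at this place, para to a large group: a 4.6-fold higher number from compound 2 to compound 3 (0.66 log units; beyond the scatter) comes with chloro in place of bromo. Moving the chlorine instead gives only a 1.1-fold higher number from compound 1 to compound 3 (0.04 log units; within the scatter) with 4-chlorophenyl in place of 3-chlorophenyl, so among these three compounds the earlier gain from compound 1 to compound 2 goes with the bromo rather than with the change of place. Nothing available here explains why the two halogens differ.

On these data alone, whether another group at this place, such as iodo, methyl or trifluoromethyl, would match or pass the bromo of compound 2 stays open. Also open, as far as these compounds go, is whether the same halogen swap would count for as much with a longer chain on the shared core.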